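This account rests on a few compounds, and the source may have more. Where it says the series, first, only, none or still open, it means among the compounds named here.

Measured so far:
- compound 1 `Oc1cccc2c1CCCC2c1c[nH]cn1`: 126 nM
- compound 2 `COc1ccc2c(c1)C(c1c[nH]cn1)CCC2`: 1770 nM
- compound 3 `COc1cccc2c1CCC=C2c1c[nH]cn1`: 2970 nM

All three were tested in an assay on cell membranes for displacement of a labelled ligand from Adrenergic receptor alpha-1 (Rattus norvegicus); a higher number here means a weaker inhibitor, a lower number a stronger inhibitor. Among the three numbers, compound 3 has the highest one. Its nearest neighbour is compound 2, whose number lies within the usual scatter of such measurements, so the two cannot be told apart. Its furthest neighbour is compound 1, which shows a far lower number in this assay, a gap well beyond the scatter.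

Compound 4 `Cc1cccc2c1CCC=C2c1c[nH]cn1` has not yet been measured. It differs from compound 3 in one place: methyl in place of methoxy on an aromatic carbon. Within the data shown here, no pair among the measured compounds shows this exchange of methoxy for methyl, so the size and direction of the step are not known from the data. With nothing to go on beyond the change itself, the expectation is a step of no certain direction, most likely staying within the scatter of this assay. On that basis the step of a 1.2-fold lower number from compound 3 to compound 4 (0.07 log units; within the scatter) is expected. Compound 4 is therefore estimated at 2500 nM, with a range from 800 nM to 8000 nM.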

Compound 4, inhibition constant: 992 nM
For compound 4 the middle estimate is 2.5-fold (0.40 log units) above the measured one, and the stated range covers the measured number.
By their numbers in this assay, from the lowest: compound 1; then compounds 4, 2 and 3 (each within the scatter of the next, the first and the last beyond it).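

On this aromatic carbon, methyl in place of methoxy gives in this assay a 3.0-fold lower number from compound 3 to compound 4 (0.48 log units; beyond the scatter) and so moves the number beyond the scatter, a modest step but the first one measured at this position. The exchange removes one heavy atom and the oxygen with its hydrogen-bond acceptor, and the number goes down rather than up, so this position does respond to the group placed on it. Nothing at hand accounts for the direction or size of this step.

On these data alone, whether a chlorine atom, an ethyl chain or an amine at this position would lower the number further remains open. Compound 1 differs from compound 3 in more than one place, so how much of their gap belongs to the hydroxy group alone cannot be read.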